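Adding Chlorine to Compound 1: An Expected Shift

The source may hold more compounds than are shown below. What is called first, only, known or untested is meant among the compounds shown, and "the series" means these compounds.

Compound 1 `Cc1ccc2c(c1)C(=O)/C(=C/c1ccccc1)CN2CC(=O)O` stands lowest of the three numbers measured in an assay on HL-60 cells for inhibition of glutathione S-transferase P (Homo sapiens), read by spectrophotometry, tested at 20 uM; a lower number here means less inhibition, a higher number more inhibition at the concentration tested (going by the name of the read-out): compound 1 gives 4.23%. Compound 2 `COc1ccc(/C=C2\CN(CC(=O)O)c3c(Cl)cccc3C2=O)c(OC)c1OC` gives 23.6% in this assay, and compound 3 `COc1cc(/C=C2\CN(CC(=O)O)c3ccc(C)cc3C2=O)cc(OC)c1` gives 23.8%; both sit beyond the scatter above compound 1 and within the scatter of each other. For the measured compounds named here, no single-change step between measured compounds is available. Compound 4 `Cc1ccc2c(c1)C(=O)/C(=C/c1ccc(Cl)cc1)CN2CC(=O)O` differs from compound 1 in one place: chloro in place of hydrogen on an aromatic carbon. With chloro entering on an aromatic carbon of a six-membered aromatic ring of carbon only, a small rise in this assay is expected, possibly within the scatter, because compound 1 gives 4.23% and the other measured compounds sit higher. Compound 4 is estimated at 12%, with a range from 0% to 28%. The expected step is a number 7.8 percentage points higher from compound 1 to compound 4 (within the scatter).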

Compound 4, a percentage reported as inhibition, at one concentration (the size of the read-out at that concentration, not a potency): 20.7%
Estimate against measurement, compound 4: 8.7 percentage points below; the range from low to high includes it.
By their numbers in this assay, from the lowest: compound 1; then compounds 4, 2 and 3 (each within the scatter of the next).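

For the compounds shown here, the change from phenyl to 4-chlorophenyl is the first single change that can be read in this assay, and it gives a number 16.5 percentage points higher from compound 1 to compound 4 (beyond the scatter) with nothing else in the structure altered. Going by these compounds alone, the earlier compounds differ from one another in more than one place, so only this pair shows that this aromatic carbon, para to a large group, responds to a single added chlorine. Nothing at hand accounts for the rise. As far as these compounds go, whether fluoro, a nitrile or an amine at this same carbon would move the number stays open, as does whether chloro on another carbon of this ring would do the same.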